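A Methyl Replaces Chloro on a Shared Core

A few compounds are considered here, and "the series" means these few. Any claim that something is new, unique, unknown or untested is made for them only; others in the source may bear on it.

Compound 2 `O=c1oc(-c2ccccc2I)nc2cc(Cl)ccc12` carries an iodine on its pendant ring and a chloro group on the shared core. In an assay on isolated protein for inhibition of complement C1r subcomponent (Homo sapiens) (on this read-out lower numbers stand for stronger inhibition and higher numbers for weaker inhibition), compound 2 gives only a limit, > 62500 nM. Compound 1 `O=c1oc(-c2ccc(I)cc2)nc2ccccc12` differs in where the iodine sits and lacks the chloro group; in this assay compound 1 likewise gives only a limit, > 62500 nM. Compound 3 `O=c1oc(-c2ccccc2I)nc2cc(Cl)c(Cl)cc12` adds a second chloro to the core of compound 2, and in this assay compound 3 again gives only a limit, > 62500 nM. Within the data shown here, the one change that can be followed between measured compounds, a step that the two limits leave unreadable from compound 2 to compound 3, cannot be read, because every value shown rests at the limit of > 62500 nM in this assay, at which 3 of the 3 values shown sit. Compound 2 therefore stands nowhere in particular on the numbers shown: it sits at a limit, as do both other compounds.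

Compound 4 `Cc1ccc2c(=O)oc(-c3ccccc3I)nc2c1` has not yet been measured. It differs from compound 2 by methyl in place of chloro on an aromatic carbon, meta to a fused ring and para to a fused ring. No measured step speaks to this exchange, and the one step that is shown gives no size. The expectation for compound 4 in this assay is a value of 100000 nM, within 30000 nM to 500000 nM, which as a step that the limit leaves unreadable from compound 2 to compound 4 is expected to stay within the scatter, most likely as a further limit.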

Compound 4, half-maximal inhibitory concentration: > 62500 nM
Compound 4 was reported as a limit (the forecaster's own chance of this, stated with the estimate: 85%); the middle value lies beyond the limit too.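

The exchange of chloro for methyl from compound 2 to compound 4 gives no step that can be read, as both compounds are reported only as limits: the limit of > 62500 nM in this assay, at which 4 of the 4 values shown sit.

The compounds shown leave open whether any change on the shared core or the pendant ring alters inhibition in this assay at all.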